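Removing Cyclohexylmethoxy from Compound 1: An Untested Step

The source may report more compounds than this note shows. Statements on the series, on what has been measured and on what is new or still open speak of the compounds shown alone.

Compound 1, `O=c1c(Cc2coc3cccc(OCC4CCCCC4)c3c2=O)coc2ccccc12`, gives 3530 nM in a functional assay on NUGC-3 cells (Homo sapiens) for antiproliferative activity, read by XTT assay; on this read-out higher numbers stand for weaker inhibition and lower numbers for stronger inhibition.
Compound 2, `COc1ccc2c(=O)c(Cc3coc4cccc(OCC5CCCCC5)c4c3=O)coc2c1`, gives 1440 nM in this assay.
Compound 3, `O=c1c(Cc2coc3cccc(OCC4CCCCC4)c3c2=O)coc2cc(O)ccc12`, gives 3220 nM in this assay.

Compound 1 stands at the highest of the three numbers in this assay. Compound 3 sits close to it, and the two values are within the scatter of each other. Compound 2 stands further off, with a 2.5-fold lower number from compound 1 to compound 2 (0.39 log units; beyond the scatter). Between compound 2 and compound 3 the step is a 2.2-fold higher number from compound 2 to compound 3 (0.35 log units; beyond the scatter), and between compound 1 and compound 3 it is a 1.1-fold lower number from compound 1 to compound 3 (0.04 log units; within the scatter).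

Compound 4, `O=c1c(Cc2coc3ccccc3c2=O)coc2ccccc12`, differs from compound 1 in one place: hydrogen in place of cyclohexylmethoxy on an aromatic carbon. Among the measured compounds shown here, none of the measured steps touches this change. All three measured compounds carry the cyclohexylmethoxy group, and the steps among them concern methoxy or hydroxy on the other ring, so they give no direct guide to the size or direction of this step in this assay. The change removes a larger piece than any of the measured steps altered, and the estimate is therefore wide. Compound 4 is expected to give 8000 nM, with a range from 2500 nM to 25000 nM. This estimate means a 2.3-fold higher number from compound 1 to compound 4 (0.36 log units; beyond the scatter).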

Compound 4, half-maximal inhibitory concentration: 7770 nM
Compound 4: the middle estimate sits 1.0-fold (0.01 log units) above what was measured; low and high end bracket the measured number.
By their numbers in this assay, from the lowest: compound 2; then compounds 3 and 1 (each within the scatter of the next); then compound 4.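

In this assay, among the compounds shown here, replacing cyclohexylmethoxy with hydrogen on this aromatic carbon gives a 2.2-fold higher number from compound 1 to compound 4 (0.34 log units; beyond the scatter), the first reading at this position, since compounds 1, 2 and 3 all carry the group. The step is modest and beyond the scatter: the cyclohexylmethoxy group goes with a lower number in this pair, yet compound 4, with only hydrogen there, still gives 7770 nM, so antiproliferative activity on this read-out does not vanish with the loss of the group. No measurement here accounts for the shift, and its origin stays unexplained.

Going by these compounds, only the two ends of the change are known at this position, the full cyclohexylmethoxy group and bare hydrogen, so it remains open whether a butoxy chain, a benzyloxy group or an amine on the same carbon would give a number nearer to compound 1 or to compound 4. Also open, on these data alone, is whether the methoxy group behind a 2.5-fold lower number from compound 1 to compound 2 (0.39 log units; beyond the scatter) would lower the number in the same way on the core of compound 4, where cyclohexylmethoxy is absent.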